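Swapping Pyrrolidin-1-yl for Pentyloxy on a Shared Core

The source may report more compounds than this note shows. Statements on the series, on what has been measured and on what is new or still open speak of the compounds shown alone.

In an ADME assay on Akata cells (Homo sapiens) for cytotoxicity, with a stated time of 7 days (on this read-out higher numbers stand for lower toxicity in this test and lower numbers for higher toxicity in this test), three compounds that share one core have so far given only limits and no exact numbers. Compound 1 `Nc1nc(OCC(F)(F)F)c2ncn(/C=C3/CC3(CO)CO)c2n1`, which carries 2,2,2-trifluoroethoxy, gives > 20000 nM, a limit of the assay. Compound 2 `CCCSc1nc(N)nc2c1ncn2/C=C1/CC1(CO)CO`, which carries propylsulfanyl, gives > 20000 nM, also a limit. Compound 3 `Nc1nc(N2CCCC2)c2ncn(/C=C3/CC3(CO)CO)c2n1`, which carries pyrrolidin-1-yl, gives > 24000 nM, again a limit.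

Compound 4 `CCCCCOc1nc(N)nc2c1ncn2/C=C1/CC1(CO)CO` has not yet been measured. The change from its neighbour is pentyloxy in place of pyrrolidin-1-yl on an aromatic carbon. In words, pentyloxy stands in place of pyrrolidin-1-yl on an aromatic carbon, so an open chain replaces a five-membered non-aromatic ring.

Three measured steps swap groups at this same place: a step that the two limits leave unreadable from compound 1 to compound 3, a step that the two limits leave unreadable from compound 2 to compound 3 and a step that the two limits leave unreadable from compound 1 to compound 2. None of them has a size that can be read, so they point in no direction. The open chain is new to this set, which leaves some room for surprise, but no step beyond the usual scatter is expected in this assay. The expected step is a number no higher from compound 3 to compound 4 (the limit leaves the size open). For compound 4 the estimate is 24000 nM, with an expected range from 9000 nM to 60000 nM.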

Compound 4, half-maximal cytotoxic concentration: > 20000 nM
Compound 4 was reported as a limit; the forecaster's own chance of this, stated with the estimate: 70%; the middle value does not contradict the limit.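

In this assay compound 4, like compound 1, compound 2 and compound 3, gives only a limit and no exact number, so none of its steps to those three compounds can be read. The four compounds leave open whether swapping the group at this place changes the read-out at all, and at what concentration each would reach the half-maximal cytotoxic effect.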